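The compounds below may be only part of what the source reports. "The series", "measured", "known", "first", "only" and "open" are said of these compounds alone.

Measured in a functional assay on MDA-MB-231 cells (Homo sapiens) for antiproliferative activity, read by MTT assay, with a stated time of 72 h; on this read-out higher numbers stand for weaker inhibition and lower numbers for stronger inhibition:
Compound 1 `CC1=CC[C@H]2[C@H](CC[C@]2(C)O)C(C)(C)[C@@H]1CC[C@H]1[C@]2(C)CC[C@H](OC(=O)c3ccc(C)cc3)C(C)(C)O[C@H]2CC[C@@]1(C)O` gives 33400 nM
Compound 2 `CC1=CC[C@H]2[C@H](CC[C@]2(C)O)C(C)(C)[C@@H]1CC[C@H]1[C@]2(C)CC[C@H](OC(=O)NCc3ccccc3)C(C)(C)O[C@H]2CC[C@@]1(C)O` gives 40300 nM
Compound 3 `COc1ccc(C(=O)O[C@H]2CC[C@]3(C)[C@H](CC[C@@](C)(O)[C@H]3CC[C@@H]3C(C)=CC[C@H]4[C@H](CC[C@]4(C)O)C3(C)C)OC2(C)C)cc1` gives 30600 nM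

These three compounds share one core and differ only in the group on a carbonyl carbon. Compound 3 cannot be told apart from the other two on these numbers. The two steps that reach it are a 1.1-fold lower number from compound 1 to compound 3 (0.04 log units; within the scatter) and a 1.3-fold lower number from compound 2 to compound 3 (0.12 log units; within the scatter), and the remaining step is a 1.2-fold higher number from compound 1 to compound 2 (0.08 log units; within the scatter).

Compound 4 `CC1=CC[C@H]2[C@H](CC[C@]2(C)O)C(C)(C)[C@@H]1CC[C@H]1[C@]2(C)CC[C@H](OC(=O)c3ccc(C(F)(F)F)cc3F)C(C)(C)O[C@H]2CC[C@@]1(C)O` keeps the same core and differs from compound 3 as follows: 2-fluoro-4-(trifluoromethyl)phenyl in place of 4-methoxyphenyl on a carbonyl carbon. In short, 2-fluoro-4-(trifluoromethyl)phenyl stands in place of 4-methoxyphenyl on a carbonyl carbon. Going by the values given here, no measured compound carries fluorine, so this exact swap has no direct precedent. The nearest guides are the small swap on the aromatic ring, a 1.1-fold lower number from compound 1 to compound 3 (0.04 log units; within the scatter), and the larger swap of the whole group, a 1.3-fold lower number from compound 2 to compound 3 (0.12 log units; within the scatter). Neither moved the number beyond the scatter.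

The expected change is therefore small, with no direction favoured: a 1.0-fold lower number from compound 3 to compound 4 (0.01 log units; within the scatter). For compound 4 the estimated value is 30000 nM, with an expected range from 15000 nM to 55000 nM.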

Compound 4, half-maximal inhibitory concentration: 36300 nM
Beside the measured number, compound 4's estimate is 1.2-fold (0.08 log units) below it; measured number inside the range.
By their numbers in this assay, from the lowest: compounds 3, 1, 4 and 2 (each within the scatter of the next).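

In this assay, going by these compounds alone, the first fluorine-bearing group at this carbonyl carbon, 2-fluoro-4-(trifluoromethyl)phenyl, cannot be told apart from the three earlier groups: the steps are a 1.2-fold higher number from compound 3 to compound 4 (0.07 log units; within the scatter), a 1.1-fold higher number from compound 1 to compound 4 (0.04 log units; within the scatter) and a 1.1-fold lower number from compound 2 to compound 4 (0.05 log units; within the scatter). The position therefore accepts a group with no hydrogen-bond acceptor in place of 4-methoxyphenyl, and with more heavy atoms, without any step beyond the scatter, so all four compounds remain level on these numbers. Nothing available explains why the number stays level across these groups.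

On these data alone, all four groups contain a six-membered aromatic ring, so it remains open whether an amine, a carboxylic acid or a longer alkyl chain on this carbonyl carbon would move the number. As far as these compounds go, what replacing the hydroxyl groups on the shared core would do also remains open.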